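Swapping the Amide Substituent of Compound 2

This account rests on a few compounds, and the source may have more. Where it says the series, first, only, none or still open, it means among the compounds named here.

In a physicochemical assay for solubility, read by spectrophotometry, measured as kinetic solubility, at pH 8, tested at 500 uM (on this read-out higher numbers stand for higher solubility and lower numbers for lower solubility), compound 1 `CN(C)C(=O)c1ccncc1Nc1cc(-c2ccc3ccn(C)c3c2)c2nccnc2c1` gives 175 ug/mL and compound 2 `Cn1cc(CNC(=O)c2ccncc2Nc2cc(-c3ccc4ccn(C)c4c3)c3nccnc3c2)cn1` gives 127 ug/mL. These two values lie within the scatter of each other, so compound 2 cannot be ranked apart from compound 1. The next analogue, compound 3 `CN1CCC(NC(=O)c2ccncc2Nc2cc(-c3ccc4ccn(C)c4c3)c3nccnc3c2)CC1`, carries 1-methylpiperidin-4-yl in place of (1-methyl-1H-pyrazol-4-yl)methyl on an amide-type nitrogen. For the measured compounds named here, only one measured step bears on this change: a 1.4-fold lower number from compound 1 to compound 2 (0.14 log units; within the scatter), which stays within the scatter although ((1-methyl-1H-pyrazol-4-yl)methyl)amino replaces dimethylamino on a carbonyl carbon. Going by the values given here, no measured compound contains the entering group, so this evidence is limited, and no shift beyond the scatter is expected in this assay. The expected change is a 1.3-fold higher number from compound 2 to compound 3 (0.10 log units; within the scatter), an estimate that stays within the scatter. Compound 3 is estimated at 160 ug/mL, with an expected range of 85 ug/mL to 240 ug/mL.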

Compound 3, solubility: 246 ug/mL
Compound 3: middle estimate off by 1.5-fold (0.19 log units), on the low side; the whole stated range lies below it.
By their numbers in this assay, from the lowest: compounds 2, 1 and 3 (each within the scatter of the next).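

Putting 1-methylpiperidin-4-yl on the amide-type nitrogen in place of (1-methyl-1H-pyrazol-4-yl)methyl gives, in this assay, a 1.9-fold higher number from compound 2 to compound 3 (0.29 log units; within the scatter), so a six-membered non-aromatic ring and a five-membered aromatic ring at this position cannot be told apart on this read-out. With (1-methylpiperidin-4-yl)amino in place of dimethylamino on the carbonyl carbon, the result is a 1.4-fold higher number from compound 1 to compound 3 (0.15 log units; within the scatter), and thus no substituent among the three compounds has yet been separated from another beyond the scatter. Nothing measured here offers an explanation for these small steps.

The compounds shown leave open whether a morpholine, a carboxylic acid or a longer chain on the amide-type nitrogen would move the number beyond the scatter. They also leave open whether changes at this position would read the same with a different shared core.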